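This account rests on a few compounds, and the source may have more. Where it says the series, first, only, none or still open, it means among the compounds named here.

Measured so far in a functional assay on DU-145 cells (Homo sapiens) for cytotoxicity, read by MTT assay, with a stated time of 24 h; on this read-out higher numbers stand for weaker inhibition and lower numbers for stronger inhibition:
- Compound 1 `Cc1ccc(/C=C2\CN(Cc3cn(Cc4ccc(F)cc4)nn3)C/C(=C\c3ccc(C)cc3)C2=O)cc1`: 49700 nM
- Compound 2 `O=C1/C(=C/c2ccccc2F)CN(Cc2cn(Cc3ccccc3Cl)nn2)C/C1=C\c1ccccc1F`: 7500 nM

Compound 1 stands highest of the two at 49700 nM, making it the weaker inhibitor, while compound 2 lies lower at 7500 nM. The gap between the two lies beyond the scatter. Compound 3 `Cc1ccc(/C=C2\CN(Cc3cn(Cc4ccccc4F)nn3)C/C(=C\c3ccc(C)cc3)C2=O)cc1` has not yet been measured. It differs from compound 1 in one place: 2-fluorophenyl in place of 4-fluorophenyl on a saturated chain carbon bound to an aromatic nitrogen. This puts 2-fluorophenyl in place of 4-fluorophenyl on a saturated chain carbon bound to an aromatic nitrogen, or 4-fluorobenzyl to 2-fluorobenzyl. For the measured compounds named here, no measured pair shows this change alone, so the expectation rests on little. Compound 2 at 7500 nM differs from compound 1 in several places, but it hints at a downward direction. In this assay the expected 1.8-fold lower number from compound 1 to compound 3 (0.25 log units; within the scatter) is modest, and it may not exceed the scatter. For compound 3 the estimated value is 28000 nM, with an expected range of 9000 nM to 70000 nM.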

Compound 3, half-maximal inhibitory concentration: 9500 nM
Compound 3: the middle estimate sits 2.9-fold (0.47 log units) above what was measured, and the stated range covers the measured number.
By their numbers in this assay, from the lowest: compounds 2 and 3 (each within the scatter of the next); then compound 1.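

In this assay, 2-fluorophenyl in place of 4-fluorophenyl, on a saturated chain carbon bound to an aromatic nitrogen, gives a 5.2-fold lower number from compound 1 to compound 3 (0.72 log units; beyond the scatter). For the compounds shown here, this is the first comparison here that isolates a single place, and it shows that this position responds to a change that leaves the atom count untouched: 4-fluorobenzyl and 2-fluorobenzyl hold the same atoms, joined differently. No measurement at hand accounts for the shift.

This single pair leaves open whether the same change would give a similar step with other groups on the rest of the core. It also leaves open how an unsubstituted benzyl group, a methoxy group on the phenyl ring or a longer chain in place of the benzyl carbon would read at this position.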